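The source may hold more compounds than are shown below. What is called first, only, known or untested is meant among the compounds shown, and "the series" means these compounds.

Compound 1 `Cc1nc2c3ccccc3ccc2c2nc3c(ccc4ccccc43)c(-c3ccccc3S)c12`: 3190 nM
Compound 2 `Cc1nc2c3ccccc3ccc2c2nc3c(ccc4ccccc43)c(-c3nccnc3N)c12`: 1210 nM

In a functional assay on HeLa cells (Homo sapiens) for cytotoxicity, read by MTT assay, with a stated time of 48 h (on this read-out lower numbers stand for stronger inhibition and higher numbers for weaker inhibition), compound 2 holds the lowest of the two numbers, with compound 1 above it by a 2.6-fold lower number from compound 1 to compound 2 (0.42 log units; beyond the scatter). Compound 3 `Cc1nc2c3ccccc3ccc2c2nc3c(ccc4ccccc43)c(-c3cc(O)nc4ccccc34)c12` differs from compound 2 in one place: 2-hydroxyquinolin-4-yl in place of 3-aminopyrazin-2-yl on an aromatic carbon. Going by the values given here, the single measured step, a 2.6-fold lower number from compound 1 to compound 2 (0.42 log units; beyond the scatter), concerns another replacement on the same aromatic carbon and was modest, so the expectation for compound 3 is a step of about that size or smaller, in either direction. For compound 3 the estimate is 1800 nM, between 700 nM and 4500 nM, meaning an expected step of a 1.5-fold higher number from compound 2 to compound 3 (0.17 log units; within the scatter).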

Compound 3, half-maximal inhibitory concentration: 4880 nM
Compound 3: the middle estimate sits 2.7-fold (0.43 log units) below what was measured; measured number outside the range, above it.
By their numbers in this assay, from the lowest: compound 2; then compounds 1 and 3 (each within the scatter of the next).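

On this aromatic carbon, opposite the ring nitrogen, 2-hydroxyquinolin-4-yl does not keep the lower number seen with 3-aminopyrazin-2-yl (a 4.0-fold higher number from compound 2 to compound 3 (0.61 log units; beyond the scatter)). Its exchange for 2-sulfanylphenyl stays within the scatter (a 1.5-fold higher number from compound 1 to compound 3 (0.18 log units; within the scatter)), so of these three groups, only 3-aminopyrazin-2-yl stands apart. Nothing available explains this difference.

Going by these compounds, it remains open whether the amine or the ring nitrogens of 3-aminopyrazin-2-yl go with the lower number. A plain pyrazin-2-yl or a 2-aminophenyl group at this carbon would separate the two.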